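The source may report more compounds than this note shows. Statements on the series, on what has been measured and on what is new or still open speak of the compounds shown alone.

Measured in a functional assay on the whole organism for antagonist activity, with Mus musculus as the target; on this read-out higher numbers stand for an effect only at larger amounts of compound and lower numbers for an effect already at smaller amounts:
compound 1 `CCCCCC(=O)NCC(=O)N(C)c1ccc(Cl)cc1C(=O)c1ccccc1Cl`: 1.9 mg/kg
compound 2 `CC(=O)NCC(=O)N(C)c1ccc(Cl)cc1C(=O)c1ccccc1Cl`: 2.3 mg/kg
compound 3 `CN(C(=O)CNC(=O)CN)c1ccc(Cl)cc1C(=O)c1ccccc1Cl`: 0.58 mg/kg
Not yet measured: compound 4 `CCCCC(=O)NCC(=O)N(C)c1ccc(Cl)cc1C(=O)c1ccccc1Cl`.

Compound 2 has the highest of the three numbers in this assay. Its nearest neighbour is compound 1, with a 1.2-fold higher number from compound 1 to compound 2 (0.08 log units; within the scatter), so the two stand together. The only separation seen in the set comes with the amino group: a 4.0-fold lower number from compound 2 to compound 3 (0.60 log units; beyond the scatter), and likewise a 3.3-fold lower number from compound 1 to compound 3 (0.52 log units; beyond the scatter).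

The step to compound 4 is propyl in place of hydrogen on a saturated chain carbon bound to a carbonyl carbon. Among the compounds with values here, the one measured step that bears on it is the replacement of butyl by hydrogen, a 1.2-fold higher number from compound 1 to compound 2 (0.08 log units; within the scatter), which is the same kind of change run in the opposite direction and slightly shorter. Nothing in the set separates a butyl chain from a hydrogen at this carbon, and no amino group enters here, so the steps to compound 3 do not apply. The expected step is therefore none beyond the scatter, a 1.2-fold lower number from compound 2 to compound 4 (0.06 log units; within the scatter).

Compound 4 is expected at about 2 mg/kg in this assay, with a range from 1 mg/kg to 4 mg/kg.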

Compound 4, dose for half-maximal effect: 1.3 mg/kg
For compound 4 the middle estimate is 1.5-fold (0.19 log units) above the measured one; low and high end bracket the measured number.
By their numbers in this assay, from the lowest: compound 3; then compounds 4, 1 and 2 (each within the scatter of the next).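

In this assay, compound 4 adds a propyl chain to the hydrogen and butyl already seen on the saturated chain carbon bound to a carbonyl carbon, and the three alkyl-series compounds stay together (a 1.8-fold lower number from compound 2 to compound 4 (0.25 log units; within the scatter); a 1.5-fold lower number from compound 1 to compound 4 (0.16 log units; within the scatter)). Amino in that place remains apart from this new chain length as well (a 2.2-fold higher number from compound 3 to compound 4 (0.35 log units; beyond the scatter)), so compound 3 is now separated from each of the other three compounds by a step beyond the scatter. No evidence on the cause of this pattern is available.

Chains longer than butyl at this carbon remain open, as does a branched chain. Also open, from the compounds shown here alone, are whether an amine at the end of a longer chain keeps the separation seen with compound 3, and how a carboxylic acid or a hydroxyl group would read in the same place.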